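The compounds below may be only part of what the source reports. "The series", "measured", "known", "first", "only" and "open" are said of these compounds alone.

Measured so far in a functional assay on CHO-K1 cells for antagonist activity at transient receptor potential cation channel subfamily V member 1 (Homo sapiens), read by FLIPR; a higher number here means a weaker inhibitor, a lower number a stronger inhibitor:
compound 1, `CCCCNc1nc(C(F)(F)F)ccc1CNC(=O)C(C)c1ccc(NS(C)(=O)=O)c(F)c1`, gives 9.1 nM
compound 2, `CC(C(=O)NCc1ccc(C(F)(F)F)nc1NCc1ccccc1)c1ccc(NS(C)(=O)=O)c(F)c1`, gives 15.8 nM
compound 3, `CC(C(=O)NCc1ccc(C(F)(F)F)nc1N1CCC(C(F)(F)F)CC1)c1ccc(NS(C)(=O)=O)c(F)c1`, gives 0.6 nM

Compound 3 stands lowest of the three; the steps of a 15-fold lower number from compound 1 to compound 3 (1.18 log units; beyond the scatter) and a 26-fold lower number from compound 2 to compound 3 (1.42 log units; beyond the scatter) are both large, while a 1.7-fold higher number from compound 1 to compound 2 (0.24 log units; within the scatter) is within the scatter. Compound 4, `CC(C(=O)NCc1ccc(C(F)(F)F)nc1N1CCCCCC1)c1ccc(NS(C)(=O)=O)c(F)c1`, is not yet measured; it differs from compound 3 by azepan-1-yl in place of 4-(trifluoromethyl)piperidin-1-yl on an aromatic carbon. The two large steps concern the same position and both show a cyclic amine doing markedly better than an open-chain one; compound 4 keeps a cyclic amine but drops the trifluoromethyl, for which no comparison exists. A modest rise in number in this assay is therefore expected, a 3.3-fold higher number from compound 3 to compound 4 (0.52 log units; beyond the scatter), likely staying closer to compound 3 than to compound 1. Compound 4 is estimated at 2 nM, range 0.6 nM to 8 nM.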

Compound 4, inhibition constant: 0.8 nM
Beside the measured number, compound 4's estimate is 2.5-fold (0.40 log units) above it; the measured number falls inside the stated range.
By their numbers in this assay, from the lowest: compounds 3 and 4 (each within the scatter of the next); then compounds 1 and 2 (each within the scatter of the next).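

In this assay, the step of a 1.3-fold higher number from compound 3 to compound 4 (0.12 log units; within the scatter) lies within the scatter, so azepan-1-yl matches 4-(trifluoromethyl)piperidin-1-yl at this aromatic carbon, and a trifluoromethyl on the cyclic amine is not required for a low number. The advantage over the open-chain amines holds for this second cyclic amine, with an 11-fold lower number from compound 1 to compound 4 (1.06 log units; beyond the scatter) and a 20-fold lower number from compound 2 to compound 4 (1.30 log units; beyond the scatter) both large. No available evidence bears on this result.

On these data alone, the separate contributions of ring size and the trifluoromethyl remain open, and an unsubstituted piperidine would separate them. Also open, as far as these compounds go, is whether a smaller pyrrolidine or an oxygen-bearing morpholine would keep the number this low.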